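Swapping the ring group for carbamoylmethyl in compound 4

The source may hold more compounds than are shown below. What is called first, only, known or untested is meant among the compounds shown, and "the series" means these compounds.

Within the data shown here, in an ADME assay on microsomes from liver (Homo sapiens) for metabolic stability (on this read-out lower numbers stand for a shorter-lived compound and higher numbers for a longer-lived compound), compound 3 (`CC(C)C(/C=C1/CCNC1=O)c1ccc(-c2ccc3cccc(F)c3c2)[nH]c1=O`) gives 0.987 h as the only actual number in the set. Compound 1 (`CC(C)C(Nc1nnc[nH]1)c1ccc(-c2ccc3cccc(F)c3c2)[nH]c1=O`) gives > 3 h and this is a limit of the assay. Compound 2 (`CC(C)C(c1ncc[nH]1)c1ccc(-c2ccc3cccc(F)c3c2)[nH]c1=O`) gives < 0.0667 h and this is also a limit. Compound 3 therefore sits between the two limits.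

The change to compound 4 (`CC(C)C(CC(N)=O)c1ccc(-c2ccc3cccc(F)c3c2)[nH]c1=O`) is a group of 4 heavy atoms (2 carbon, 1 nitrogen, 1 oxygen; no ring) in place of a group of 7 heavy atoms (5 carbon, 1 nitrogen, 1 oxygen; one five-membered non-aromatic ring with 1 hetero atom), on a saturated chain carbon bound to an aromatic carbon and a saturated chain carbon and the group that enters is carbamoylmethyl. All three measured steps fall at this same place: an at least 44-fold lower number from compound 1 to compound 2 (1.65 log units; beyond the scatter), then an at least 3.0-fold lower number from compound 1 to compound 3 (0.48 log units; beyond the scatter), then an at least 14-fold higher number from compound 2 to compound 3 (1.17 log units; beyond the scatter). All lie beyond the scatter, so the place is sensitive, but they run in both directions and none has a ringless group entering. The donor and acceptor counts of the leaving and entering groups match, so compound 3 remains the anchor. No clear direction is expected, and the expected change is a 1.1-fold higher number from compound 3 to compound 4 (0.05 log units; within the scatter), with a wide margin. The estimate for compound 4 is 1.1 h, with the expected range running from 0.3 h to 3 h.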

Compound 4, half-life: < 0.0667 h
Compound 4: a limit, no number; the forecaster's own chance of this, stated with the estimate: 15%; middle value at least 16-fold (1.21 log units) from the limit.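

Carbamoylmethyl and the ring group it replaces have the same donor and acceptor counts, yet the read-out moves: an at least 14-fold lower number from compound 3 to compound 4 (1.17 log units; beyond the scatter), so those counts do not settle the outcome at this place. The ringless group also falls well short of the (4H-1,2,4-triazol-3-yl)amino group, with an at least 44-fold lower number from compound 1 to compound 4 (1.65 log units; beyond the scatter), so a group with no ring can reach the short-lived end just as the ring-bearing 1H-imidazol-2-yl does. In this assay compound 4 gives a limit and not a number: the limit of < 0.0667 h in this assay, at which 2 of the 4 values shown sit.

Compound 2 and compound 4 stand at the same limit, so the step between them cannot be read. Still open, as far as these compounds go, is whether the terminal amide or the short ringless chain governs the read-out, which a carboxylic acid, a primary amine or a longer chain on this carbon could help separate.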